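Aryloxypropoxy series: estimate for compound 3 before measurement

The source may report more compounds than this note shows. Statements on the series, on what has been measured and on what is new or still open speak of the compounds shown alone.

Compound 1 `NC1=NC2(CCSCC2)N(OCCCOc2ccc(Br)cc2)C(N)=N1`: > 90%
Compound 2 `NC1=NC2(CCSCC2)N(OCCCOc2cc(Cl)c(Cl)cc2Cl)C(N)=N1`: 84.4%

In an assay on isolated protein for inhibition of Dihydrofolate reductase (Homo sapiens), read by spectrophotometry, using NADPH, with stated times of 5 s and 6 min, tested at 5 uM (a higher number here means a stronger effect of the compound at the concentration tested, a lower number a weaker effect), compound 1 gives > 90%, which is a limit of the assay (the limit of > 90% in this assay, at which 1 of the 2 values shown sits). In this assay, among the measured compounds shown here, compound 2 gives 84.4%, the only number so far. For the measured compounds named here, the single measured step, a number at least 5.6 percentage points lower from compound 1 to compound 2 (that floor lies within the scatter), has its floor within the scatter, so no firm direction is established for swapping halogen patterns on the phenyl.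

Compound 3 `NC1=NC2(CCSCC2)N(OCCCOc2ccccc2Cl)C(N)=N1` differs from compound 2 by 2-chlorophenyl in place of 2,4,5-trichlorophenyl on an oxygen on a saturated carbon. The step from compound 1 to compound 2 bears on this change only loosely, since it too alters the halogens on the phenyl, and it gave no step beyond the scatter. The step of a number 0.6 percentage points higher from compound 2 to compound 3 (within the scatter) is therefore expected to lie within the scatter. Compound 3 is expected to give 85%, in the range 70% to 95%, with some chance that only a limit is reported.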

Compound 3, a percentage reported as inhibition, at one concentration (the size of the read-out at that concentration, not a potency): 86.3%
Beside the measured number, compound 3's estimate is 1.3 percentage points below it; the range from low to high includes it.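

In this assay the change to 2-chlorophenyl from 2,4,5-trichlorophenyl (a number 1.9 percentage points higher from compound 2 to compound 3 (within the scatter)) shows that, on this oxygen on a saturated carbon, an aryl group with a single chlorine cannot be told apart from one with three. The change from 4-bromophenyl to 2-chlorophenyl (a number at least 3.7 percentage points lower from compound 1 to compound 3 (that floor lies within the scatter)) also has its floor within the scatter, so no order among the three aryl groups is established. Compound 1 is a limit of the assay, so the full size of both steps from it stays unread: the limit of > 90% in this assay, at which 1 of the 3 values shown sits.

With a single tested concentration, differences in potency among these compounds remain unresolved. Also open, on these data alone, is whether an amine or a carboxylic acid on the phenyl ring, or a longer chain on the oxygen, would move the read-out beyond the scatter.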